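This account rests on a few compounds, and the source may have more. Where it says the series, first, only, none or still open, it means among the compounds named here.

Three compounds built on a shared core have been examined in a functional assay on MCF7 cells (Homo sapiens) for inhibition, read by sulforhodamine B assay; on this read-out lower numbers stand for stronger inhibition and higher numbers for weaker inhibition. Compound 1 `CCCc1ccc(NC2=CC(=O)c3c(nc4n3[C@H]3OC[C@@H](O)[C@H]3OC4)C2=O)cc1` reaches only the limit > 4000 nM there. Compound 2 `O=C1C(N2CCCCC2)=CC(=O)c2c1nc1n2[C@H]2OC[C@@H](O)[C@H]2OC1` also reaches only the limit > 8000 nM. Compound 3 `COc1cccc(NC2=CC(=O)c3nc4n(c3C2=O)[C@H]2OC[C@@H](O)[C@H]2OC4)c1` in turn gives only the limit > 4000 nM in this assay. Two of the three compounds thus sit at the limit of > 4000 nM in this assay, at which 2 of the 3 values shown sit, and one at the limit of > 8000 nM in this assay, at which 1 of the 3 values shown sits. Compound 4 `COc1ccc(NC2=CC(=O)c3nc4n(c3C2=O)[C@H]2OC[C@@H](O)[C@H]2OC4)cc1` differs from compound 3 by 4-methoxyphenyl in place of 3-methoxyphenyl on an amine nitrogen. Among the measured compounds shown here, no step between measured compounds is available to guide this change, and nothing among the three results points to a gain, so the step is expected to be none beyond the scatter, a step that the limit leaves unreadable from compound 3 to compound 4. Compound 4 is therefore estimated at 8000 nM, within 3000 nM to 30000 nM, most likely again reported only as a limit.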

Compound 4, half-maximal inhibitory concentration: 5420 nM
For compound 4 the middle estimate is 1.5-fold (0.17 log units) above the measured one, within the range that was stated.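

Compound 3 stands only at a limit, so no step from it to compound 4 can be read: the limit of > 4000 nM in this assay, at which 2 of the 4 values shown sit.

The compounds shown leave open whether 4-methoxyphenyl in place of 3-methoxyphenyl on an amine nitrogen changes inhibition at all.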